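Benzyl swap at the ring amide nitrogen, microsomal half-life

The source may hold more compounds than are shown below. What is called first, only, known or untested is meant among the compounds shown, and "the series" means these compounds.

Working notes on the series. Compound 1 `CS(=O)(=O)Nc1ccc2c(c1)S(=O)(=O)N=C(C1=C(O)C3CCCC3N(Cc3ccccn3)C1=O)N2` is the reference. In an in vitro ADME assay on microsomes from liver (Homo sapiens) for metabolic stability (on this read-out lower numbers stand for a shorter-lived compound and higher numbers for a longer-lived compound), compound 1 gives > 1 h, which is a limit of the assay rather than a number. Compound 2 `CS(=O)(=O)Nc1ccc2c(c1)S(=O)(=O)N=C(C1=C(O)C3CCCCC3N(Cc3ccc(F)cc3)C1=O)N2` in this assay gives > 1 h, again a limit. Among the compounds with values here, both measured values therefore sit together at the top of what this assay reports (the limit of > 1 h in this assay, at which 2 of the 2 values shown sit), and no step between measured compounds can be drawn from them. Compound 1 stands at that limit, not at a resolved number.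

Compound 3 `CS(=O)(=O)Nc1ccc2c(c1)S(=O)(=O)N=C(C1=C(O)C3CCCC3N(Cc3ccc(Cl)cc3)C1=O)N2` differs from compound 1 in one place: 4-chlorophenyl in place of pyridin-2-yl on a saturated chain carbon bound to an amide-type nitrogen in a ring. Within the data shown here, with no measured step to lean on, the expected step in this assay is a step that the limit leaves unreadable from compound 1 to compound 3, in effect none beyond the usual scatter, and a further limit read-out is the likeliest outcome. Compound 3 is expected to give about 1.5 h in this assay, with a range from 0.5 h to 4 h.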

Compound 3, half-life: > 1 h
Compound 3 ended at the assay's limit (the forecaster's own chance of this, stated with the estimate: 70%); the middle value does not contradict the limit.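

Compound 1 and compound 3 both end at a limit of this assay rather than at a number, so no step between them can be read: the limit of > 1 h in this assay, at which 3 of the 3 values shown sit.

The compounds shown leave open whether 4-chlorophenyl in place of pyridin-2-yl changes the half-life at all, and in which direction.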